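The compounds below may be only part of what the source reports. "The series", "measured", "known", "first", "only" and "open" are said of these compounds alone.

Within the data shown here, compound 3 `CC1(C)CC(OC(=O)CN2CN(c3ccccc3)C3(CCN(C(=O)c4ccc(C(C)(C)C)cc4)CC3)C2=O)CC(C)(C)N1` gives 1300 nM in an assay on HEK293 cells for displacement of a labelled ligand from NPC1-like intracellular cholesterol transporter 1 (Homo sapiens) (on this read-out lower numbers stand for stronger inhibition and higher numbers for weaker inhibition), the lowest of the three numbers measured so far; compound 1 `CC(C)(C)c1ccc(C(=O)N2CCC3(CC2)C(=O)N(CC(=O)N2CCC(CCO)CC2)CN3c2ccccc2)cc1` at 2600 nM stands within the scatter of it, while compound 2 `CC(C)(C)c1ccc(C(=O)N2CCC3(CC2)C(=O)N(CC(=O)NCN)CN3c2ccccc2)cc1` at 26500 nM lies beyond it. Compound 4 `CC(C)(C)c1ccc(C(=O)N2CCC3(CC2)C(=O)N(CC(=O)NCCCCO)CN3c2ccccc2)cc1` carries (4-hydroxybutyl)amino in place of (2,2,6,6-tetramethylpiperidin-4-yl)oxy on a carbonyl carbon. Among the measured compounds shown here, two measured steps bear on this change: a 2.0-fold lower number from compound 1 to compound 3 (0.30 log units; within the scatter) leaves the two ring-bearing groups within the scatter of each other, whereas a 20-fold lower number from compound 2 to compound 3 (1.31 log units; beyond the scatter) is large. The entering (4-hydroxybutyl)amino is, like the (aminomethyl)amino of compound 2, an open chain on the carbonyl carbon, so a higher number than compound 3 is expected, though a smaller move than the step to compound 2. Compound 4 is estimated at 5500 nM, between 2000 nM and 15000 nM, an expected step of a 4.2-fold higher number from compound 3 to compound 4 (0.63 log units; beyond the scatter).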

Compound 4, half-maximal inhibitory concentration: 19200 nM
Compound 4: the middle estimate sits 3.5-fold (0.54 log units) below what was measured; the measured number lies above the stated range.
By their numbers in this assay, from the lowest: compounds 3 and 1 (each within the scatter of the next); then compounds 4 and 2 (each within the scatter of the next).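

At this carbonyl carbon, the (4-hydroxybutyl)amino chain does not hold the level of either ring-bearing group, with a 15-fold higher number from compound 3 to compound 4 (1.17 log units; beyond the scatter) and a 7.4-fold higher number from compound 1 to compound 4 (0.87 log units; beyond the scatter), while a 1.4-fold lower number from compound 2 to compound 4 (0.14 log units; within the scatter) places it with the other open chain. Among these four compounds, the two ring-bearing groups give the lower numbers and the two open chains the higher ones, and no compound goes against this. No measurement here accounts for that split.

From the compounds shown here alone, whether a plain piperidin-1-yl amide would stay with the ring-bearing groups remains open. So does the standing of an open chain ending in a carboxylic acid.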